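Notes on the nitrogen substituent: compound 3 to compound 4

The source may report more compounds than this note shows. Statements on the series, on what has been measured and on what is new or still open speak of the compounds shown alone.

The series is read in a functional assay on a cell-free system (plasma, Oryctolagus cuniculus) for inhibition, with stated times of 5 min, 1 min and 6 min; a lower number here means a stronger inhibitor, a higher number a weaker inhibitor. Compound 1 `CCOC(=O)c1[nH]c(-c2cccc(C#N)c2)nc1C` reaches only a limit of the assay, > 30000 nM, and so gives no number (the limit of > 30000 nM in this assay, at which 1 of the 3 values shown sits). Compound 2 `CCOC(=O)c1c(C)nc(-c2cccc(C#N)c2)n1C` gives 22100 nM; the change is an at least 1.3-fold lower number from compound 1 to compound 2 (0.13 log units; that floor lies within the scatter). Compound 3 `CCOC(=O)c1c(C)nc(-c2cccc(C#N)c2)n1OCc1ccncc1` gives 6200 nM, the lowest of the two numbers shown, with a 3.6-fold lower number from compound 2 to compound 3 (0.55 log units; beyond the scatter) and an at least 4.8-fold lower number from compound 1 to compound 3 (0.68 log units; beyond the scatter).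

Compound 4 `CCOC(=O)c1c(C)nc(-c2cccc(C#N)c2)n1OCc1ccc(OC)cc1` differs from compound 3 by 4-methoxyphenyl in place of pyridin-4-yl on a saturated chain carbon bound to an oxygen on an aromatic ring. Among the measured compounds shown here, no measured step alters the ring at the end of that chain; the steps in this assay all concern what sits on the aromatic nitrogen itself, and the largest of them, a 3.6-fold lower number from compound 2 to compound 3 (0.55 log units; beyond the scatter), shows that the whole (pyridin-4-yl)methoxy group matters more than methyl. Going by these compounds, how much of that rests on the pyridin-4-yl ring is untested, so the step from compound 3 is expected to stay close to the scatter, a 1.2-fold lower number from compound 3 to compound 4 (0.09 log units; within the scatter), with a wide margin either way. Compound 4 is therefore estimated at 5000 nM, between 1500 nM and 16000 nM.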

Compound 4, half-maximal inhibitory concentration: 6830 nM
Compound 4: middle estimate off by 1.4-fold (0.14 log units), on the low side, and the stated range covers the measured number.
By their numbers in this assay, from the lowest: compounds 3 and 4 (each within the scatter of the next); then compound 2. At a limit, above all of these: compound 1.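

In this assay this is the only step shown that changes the ring at the end of the chain rather than the group on the aromatic nitrogen itself: 4-methoxyphenyl in place of pyridin-4-yl gives a 1.1-fold higher number from compound 3 to compound 4 (0.04 log units; within the scatter) and leaves the two compounds reading alike. In this pair, the ring nitrogen of pyridin-4-yl is not needed to hold the number at this level, and a ring of carbon only, carrying a methoxy group, serves as well. Nothing at hand accounts for the two rings reading alike.

Open, going by these compounds, is whether a plain benzyl group without the methoxy, a longer chain, or an end group with no ring at all, such as an amine or a carboxylic acid, reads the same. Also open, on these data alone, is whether any change at this end of the chain can move the number beyond the scatter.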